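The source may report more compounds than this note shows. Statements on the series, on what has been measured and on what is new or still open speak of the compounds shown alone.

Of the compounds shown here, three have been measured in an ADME assay for pharmacokinetics, read by LC-MS, in phosphate buffer, with a stated time of 72 h, at pH 7.4, tested at 250 uM; a higher number here means that the compound lasts longer, a lower number that the compound disappears faster. Compound 1 `C=CS(=O)(=O)c1cc(C(F)(F)F)cc(C(F)(F)F)c1` gives < 0.017 h, which is a limit of the assay. Compound 2 `O=C1C=CC(=O)N1c1cc(C(F)(F)F)cc(C(F)(F)F)c1` likewise gives < 0.017 h, again a limit. Compound 3 `O=C(CBr)c1cc(C(F)(F)F)cc(C(F)(F)F)c1` gives < 0.017 h, also a limit. All three values sit at the same limit (the limit of < 0.017 h in this assay, at which 3 of the 3 values shown sit), so the steps a step that the two limits leave unreadable from compound 1 to compound 3 and a step that the two limits leave unreadable from compound 2 to compound 3 have no readable size. Compound 4 `FC(F)(F)c1cc(S)cc(C(F)(F)F)c1` differs from compound 3 by sulfanyl in place of (bromomethyl)carbonyl on an aromatic carbon. Within the data shown here, no measured step gives a size for this change, since each joins two limits. Because every measured compound stands at the limit of < 0.017 h in this assay, at which 3 of the 3 values shown sit, while compound 4 carries none of their groups, the step of an at least 1400-fold higher number from compound 3 to compound 4 (3.14 log units; beyond the scatter) is expected to run upward in half-life. Compound 4 is therefore expected to give 24 h in this assay, within 4 h to 150 h.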

Compound 4, half-life: 33 h
Estimate against measurement, compound 4: 1.4-fold (0.14 log units) below, and the stated range covers the measured number.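

Putting sulfanyl on this aromatic carbon brings an at least 1900-fold higher number from compound 3 to compound 4 (3.28 log units; beyond the scatter), and the other two groups give the same picture, with an at least 1900-fold higher number from compound 2 to compound 4 (3.28 log units; beyond the scatter) and an at least 1900-fold higher number from compound 1 to compound 4 (3.28 log units; beyond the scatter). Each of these steps starts from a limit, so each gives only a lower bound on the change. Compound 4 alone stands clear of the limit, so the shared core does not by itself keep a compound there: the limit of < 0.017 h in this assay, at which 3 of the 4 values shown sit.

The steps among compound 1, compound 2 and compound 3 cannot be read. As far as these compounds go, whether a hydroxyl, an amine or a methylthio group at this place would also last in this assay remains open.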